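The source may report more compounds than this note shows. Statements on the series, on what has been measured and on what is new or still open speak of the compounds shown alone.

Compound 1 `CN1C[C@H](C(=O)Nc2ccc(Br)cc2)[C@@H](c2ccc(/C=C/C(=O)Nc3ccccc3N)cc2)C1`: 3 mL/min/kg
Compound 2 `CN1C[C@H](C(=O)Nc2ccc(F)cc2F)[C@@H](c2ccc(/C=C/C(=O)Nc3ccccc3N)cc2)C1`: 12 mL/min/kg
Compound 3 `CN1C[C@H](C(=O)Nc2ccccn2)[C@@H](c2ccc(/C=C/C(=O)Nc3ccccc3N)cc2)C1`: 8 mL/min/kg

In an in vitro ADME assay on microsomes from liver (Homo sapiens) for pharmacokinetics, read by LC-MS, with a stated time of 10 min, tested at 1 uM (a higher number here means faster removal of the compound, a lower number slower removal), compound 3 gives 8 mL/min/kg. It stands clear of the 4-bromophenyl amide, with a 2.7-fold higher number from compound 1 to compound 3 (0.43 log units; beyond the scatter). It cannot be separated from the 2,4-difluorophenyl amide, with a 1.5-fold lower number from compound 2 to compound 3 (0.18 log units; within the scatter).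

Compound 4 `CC(C)NC(=O)[C@H]1CN(C)C[C@@H]1c1ccc(/C=C/C(=O)Nc2ccccc2N)cc1` keeps the shared core and carries isopropyl in place of pyridin-2-yl on an amide-type nitrogen. Within the data shown here, all three measured steps change this same place, so they are the only guide, yet each exchanges one ring for another. The largest, a 4.0-fold higher number from compound 1 to compound 2 (0.60 log units; beyond the scatter), is modest, and it starts from the lowest number of the set. Among the measured compounds shown here, no measured compound has an open-chain group here, so the direction of any move in this assay cannot be read from the data, and the range must stay wide. The expected result is a 1.1-fold higher number from compound 3 to compound 4 (0.05 log units; within the scatter), which means no expected change beyond the scatter. For compound 4 the estimated clearance is 9 mL/min/kg, with an expected range of 3 mL/min/kg to 25 mL/min/kg.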

Compound 4, clearance: 8 mL/min/kg
Estimate against measurement, compound 4: 1.1-fold (0.05 log units) above; measured number inside the range.
By their numbers in this assay, from the lowest: compound 1; then compounds 3, 4 and 2 (each within the scatter of the next).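

In this assay, among these compounds, the first open-chain group at this amide-type nitrogen cannot be separated from the ring-bearing amides, with no change at the digits printed from compound 3 to compound 4 (within the scatter) and a 1.5-fold lower number from compound 2 to compound 4 (0.18 log units; within the scatter), so among compounds 2, 3 and 4 a ring here makes no readable difference. Compound 1 goes against this, with a 2.7-fold higher number from compound 1 to compound 4 (0.43 log units; beyond the scatter), and the 4-bromophenyl amide now stands apart from an open-chain group as well as from two rings. Nothing available bears on why isopropyl and pyridin-2-yl give matching numbers.

The compounds shown leave open whether the separation of compound 1 belongs to the bromine or to the phenyl ring, and an unsubstituted phenyl amide would address that. One branched chain also says nothing about a longer chain such as n-butyl, or about a chain ending in an amine or a carboxylic acid.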